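Quinolin-8-yl for pyrimidin-4-yl in a ketone series

This account rests on a few compounds, and the source may have more. Where it says the series, first, only, none or still open, it means among the compounds named here.

Measured compounds:
compound 1, `CC(C)[C@H](NC(=O)COc1cccc2ccccc12)C(=O)N[C@@H](CC(=O)O)C(=O)COc1cc(C(F)(F)F)n(C)n1`, 46000 nM
compound 2, `CC(C)[C@H](NC(=O)COc1cccc2ccccc12)C(=O)N[C@@H](CC(=O)O)C(=O)COc1ccncn1`, > 200000 nM

In a functional assay on Jurkat cells (Homo sapiens) for inhibition (on this read-out lower numbers stand for stronger inhibition and higher numbers for weaker inhibition), compound 1 gives 46000 nM. For compound 2 this assay reports only a limit, > 200000 nM, so its true number is not known. Going by the values given here, the one measured step, an at least 4.3-fold higher number from compound 1 to compound 2 (0.63 log units; beyond the scatter), moves onto the limit (the limit of > 200000 nM in this assay, at which 1 of the 2 values shown sits). Compound 3, `CC(C)[C@H](NC(=O)COc1cccc2ccccc12)C(=O)N[C@@H](CC(=O)O)C(=O)COc1cccc2cccnc12`, carries the change (quinolin-8-yl in place of pyrimidin-4-yl on an oxygen on a saturated carbon). Among the compounds with values here, no measured step covers this change; the only comparison available is the one step from compound 1 to compound 2, which shows that exchanging this aryl group can shift the number beyond the scatter. Starting from a limit, the step of an at least 1.6-fold lower number from compound 2 to compound 3 (0.22 log units; that floor lies within the scatter) is therefore expected to be unclear in direction and possibly none beyond the scatter. Compound 3 is estimated at 120000 nM, within 25000 nM to 400000 nM.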

Compound 3, half-maximal inhibitory concentration: > 200000 nM
Compound 3: no number, only a limit; the forecaster's own chance of this, stated with the estimate: 50%; middle value at least 1.6-fold (0.22 log units) away from the limit.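

In this assay compound 3 also gives only a limit, > 200000 nM. Pyrimidin-4-yl is therefore no longer the only group on this oxygen to lose the measurable value of compound 1: quinolin-8-yl gives an at least 4.3-fold higher number from compound 1 to compound 3 (0.63 log units; beyond the scatter), and 1-methyl-5-(trifluoromethyl)-1H-pyrazol-3-yl remains the only group here with a measured number. The step from compound 2 to compound 3 cannot be read, and the two groups cannot be ordered, because both values are limits: the limit of > 200000 nM in this assay, at which 2 of the 3 values shown sit.

On these data alone, it remains open how far compound 2 and compound 3 lie beyond that limit. As far as these compounds go, it is also open which part of the pyrazole group goes with the measurable value, for instance whether a pyrazole with methyl in place of trifluoromethyl, or a phenyl ring carrying trifluoromethyl, would still give a number.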